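One More Ethyl on the Chain of Compound 2

The source may hold more compounds than are shown below. What is called first, only, known or untested is meant among the compounds shown, and "the series" means these compounds.

In a functional assay, with a stated time of 30 min (on this read-out higher numbers stand for weaker inhibition and lower numbers for stronger inhibition), compound 1 (`CCOc1cc(OC)ccc1C(C)=O`) gives 39600000 nM, and compound 2 (`CCCCOc1cc(OC)ccc1C(C)=O`) gives 43300000 nM. For the measured compounds named here, these two numbers lie within the usual scatter of each other, so compound 2 stands level with its only measured neighbour. The change to compound 3 (`CCCCCCOc1cc(OC)ccc1C(C)=O`) is ethyl in place of hydrogen on a saturated chain carbon, four bonds along the chain from an oxygen on an aromatic ring, with ethyl in place of hydrogen on a saturated chain carbon, four bonds along the chain from an oxygen on an aromatic ring. Going by the values given here, only one measured step bears on this, the same swap made two bonds along the chain from that oxygen: a 1.1-fold higher number from compound 1 to compound 2 (0.04 log units; within the scatter). That step stayed within the scatter. One step is thin evidence, but it gives no reason to expect a real shift in this assay now. The expected step is a 1.0-fold higher number from compound 2 to compound 3 (0.02 log units; within the scatter), which is none beyond the scatter. For compound 3 the estimate is 45000000 nM, with an expected range from 20000000 nM to 90000000 nM.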

Compound 3, half-maximal inhibitory concentration: 42600000 nM
The estimate for compound 3 lay 1.1-fold (0.02 log units) above the measured number; the range from low to high includes it.
By their numbers in this assay, from the lowest: compounds 1, 3 and 2 (each within the scatter of the next).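

Adding ethyl four bonds along the chain from an oxygen on an aromatic ring does not move the number in this assay (a 1.0-fold lower number from compound 2 to compound 3 (0.01 log units; within the scatter)), so the second extension behaves like the first. Read across the whole stretch, butyl in place of hydrogen two bonds along the chain from that oxygen also stays within the scatter (a 1.1-fold higher number from compound 1 to compound 3 (0.03 log units; within the scatter)), which means that compound 1, compound 2 and compound 3 now form a flat series of three rather than a single level pair. No supporting measurement is available to explain why the numbers stay level.

The compounds shown do not reveal whether this flat behaviour continues with a longer chain than that of compound 3. They also leave open whether an amine or a carboxylic acid at the end of the chain would shift the number beyond the scatter.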